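The source may hold more compounds than are shown below. What is called first, only, known or untested is meant among the compounds shown, and "the series" means these compounds.

The measured compounds are compound 1 `CNC(=O)c1cccn(Cc2ccccc2)c1=O`, compound 2 `CNC(=O)c1cc(C(=O)NC2CC2)c(C)n(Cc2ccccc2)c1=O` and compound 3 `CNC(=O)c1cc(C(=O)NC2CC2)cn(Cc2cccc3[nH]ccc23)c1=O`. In a physicochemical assay for solubility (a lower number here means a less soluble compound, a higher number a more soluble compound), compound 1 gives 78 ug/mL. For compound 2 the result in this assay is a limit of the assay, >= 126 ug/mL, not a number. Compound 3 gives 78 ug/mL in this assay and so stands level with compound 1, within the usual scatter. No pair among these three differs in one place only, so no single measured step can be followed. Compound 4 `CNC(=O)c1cc(C(=O)NC2CC2)cn(CC2CCOCC2)c1=O` differs from compound 3 by one change: oxan-4-yl in place of 1H-indol-4-yl on a saturated chain carbon bound to an aromatic nitrogen. The measured compounds give no direct guide to this change. The step is nevertheless expected to raise solubility modestly, a 1.9-fold higher number from compound 3 to compound 4 (0.28 log units; within the scatter). Compound 4 is estimated at 150 ug/mL, with a range from 60 ug/mL to 400 ug/mL.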

Compound 4, solubility: >= 165 ug/mL
Compound 4: a limit, no number; the forecaster's own chance of this, stated with the estimate: 40%; at least 1.1-fold (0.04 log units) between middle value and limit.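

In this assay, the result for compound 4 is a limit of the assay, not a number: >= 165 ug/mL. At this place, on a saturated chain carbon bound to an aromatic nitrogen, putting oxan-4-yl in place of 1H-indol-4-yl gives an at least 2.1-fold higher number from compound 3 to compound 4 (0.32 log units; beyond the scatter), so this single change is beyond the scatter. The full size of the step cannot be read, as compound 4 stands at a limit: the limit of >= 165 ug/mL in this assay, at which 1 of the 4 values shown sits.

The compounds shown leave open whether the ring oxygen of oxan-4-yl matters here. Cyclohexyl at the same place would test that, and a piperidin-4-yl amine would extend the comparison.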